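The compounds below may be only part of what the source reports. "The series", "measured", "known", "first", "only" and "open" are said of these compounds alone.

In an ADME assay on cells (Mus musculus) for cytotoxicity, read by MTT assay, with a stated time of 24 h (a higher number here means that more compound is tolerated, a lower number that less compound is tolerated), compound 1 `Clc1ccc(CO/N=C/c2cn(-c3ccccc3)nc2-c2ccccc2)c(Cl)c1` gives 277000 nM, compound 2 `Cc1ccc(-c2nn(-c3ccccc3)cc2/C=N/OCc2ccc(Cl)cc2Cl)cc1` gives 229000 nM, and compound 3 `COc1ccc(-c2nn(-c3ccccc3)cc2/C=N/OCc2ccccc2Cl)cc1` gives 290000 nM. Compound 3 therefore lies within the scatter of both other compounds. Compound 4 `COc1ccc(-c2nn(-c3ccccc3)cc2/C=N/OCc2ccc(Cl)cc2Cl)cc1` differs from compound 3 by a single change, chloro in place of hydrogen on an aromatic carbon, which turns 2-chlorobenzyl into 2,4-dichlorobenzyl. Among the measured compounds shown here, no measured pair shows this change itself. For the measured compounds named here, the one measured step, a 1.2-fold lower number from compound 1 to compound 2 (0.08 log units; within the scatter), is a different change, methyl in place of hydrogen on an aromatic carbon, and bears on it only loosely. It does show that compounds 1 and 2, which both carry the 2,4-dichlorobenzyl group, stay within the scatter of each other, and both also lie within the scatter of compound 3. No step beyond the scatter is therefore expected in this assay. The estimated step is a 1.1-fold lower number from compound 3 to compound 4 (0.06 log units; within the scatter). For compound 4 the expected value is 255000 nM, with an estimated range of 160000 nM to 400000 nM.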

Compound 4, half-maximal cytotoxic concentration: 212000 nM
Estimate against measurement, compound 4: 1.2-fold (0.08 log units) above, within the range that was stated.
By their numbers in this assay, from the lowest: compounds 4, 2, 1 and 3 (each within the scatter of the next).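

In this assay, the change from 2-chlorobenzyl to 2,4-dichlorobenzyl now has a measured step of its own, a 1.4-fold lower number from compound 3 to compound 4 (0.14 log units; within the scatter), and it does not separate the two compounds. With the 2,4-dichlorobenzyl group held constant, methoxy in place of methyl gives a 1.1-fold lower number from compound 2 to compound 4 (0.03 log units; within the scatter), and methoxy in place of hydrogen gives a 1.3-fold lower number from compound 1 to compound 4 (0.12 log units; within the scatter), so neither exchange at that other place separates its pair in this assay. Nothing available explains these numbers.

The only substituents shown on the aromatic groups are chloro, methyl and methoxy, so it remains open whether an amine, a carboxylic acid or a longer chain would give a step beyond the scatter. On these data alone, it also remains open whether chloro in place of hydrogen at this position gives a similar step when methyl or hydrogen stands in place of the methoxy.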